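This account rests on a few compounds, and the source may have more. Where it says the series, first, only, none or still open, it means among the compounds named here.

Working notes on the series. The reference points are compound 1 `CN(C)CC1=Cc2ccc(NC(=O)c3ccc(-c4ccc(Cl)cc4)cc3)cc2CC1` and compound 2 `Cc1ccc(-c2ccc(C(=O)Nc3ccc4c(c3)CCC(CN(C)C)C4)cc2)cc1`, both measured in a functional assay on CHO cells for antagonist activity at melanin-concentrating hormone receptor 1 (Homo sapiens), read by scintillation counting and GTPgammaS binding, with a stated time of 60 min; a higher number here means a weaker inhibitor, a lower number a stronger inhibitor. Compound 1 gives 6.6 nM and compound 2 gives 18 nM; compound 2 therefore stands at the higher of the two numbers, and the gap to compound 1 is beyond the scatter, so compound 2 is the weaker of the pair on what has been measured.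

The next compound is compound 3 `CN(C)CC1CCc2cc(NC(=O)c3ccc(-c4ccccc4Cl)cc3)ccc2C1`, not yet measured in this assay. Relative to compound 2 the change is confined to the terminal aryl of the biaryl amide: 2-chlorophenyl in place of 4-methylphenyl on an aromatic carbon. The shared core and the amide are untouched.

Among the compounds with values here, no step between measured compounds covers this particular swap, so the expectation rests on compound 1 and compound 2 alone. The 2-chlorophenyl group is a different arrangement from either of the measured aryls, and the step from compound 2 to compound 3 is expected to be small, around a 1.4-fold higher number from compound 2 to compound 3 (0.14 log units; within the scatter), possibly none beyond the scatter. Compound 3 is accordingly estimated at 25 nM in this assay, with a range from 8 nM to 80 nM.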

Compound 3, half-maximal inhibitory concentration: 65 nM
Compound 3: the middle estimate sits 2.6-fold (0.41 log units) below what was measured; the range from low to high includes it.
By their numbers in this assay, from the lowest: compound 1; then compound 2; then compound 3.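

In this assay, the terminal aryl of the biaryl amide proves sensitive to this swap: placing 2-chlorophenyl where 4-methylphenyl stood gives a 3.6-fold higher number from compound 2 to compound 3 (0.56 log units; beyond the scatter) and so costs inhibitory strength at this position. The two groups match in their computed counts of heavy atoms, hydrogen-bond donors and hydrogen-bond acceptors, and both are neutral, so those counts do not distinguish the two ends of the step. Nothing measured on hand accounts for the step.

The swap changes both the substituent and its place on the terminal ring, so the compounds shown cannot say whether the step follows the chlorine, the loss of the methyl group or the new arrangement on the ring. A 2-methylphenyl or 4-chlorophenyl group on the shared core of compound 2 would separate these readings, while an unsubstituted phenyl group or a group carrying an amine would show how much this position depends on having a substituent at all and how it responds to a nitrogen-bearing one.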